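The source may hold more compounds than are shown below. What is called first, only, known or untested is meant among the compounds shown, and "the series" means these compounds.

Measured in a functional assay on A 172 cells (Homo sapiens) for cytotoxicity, read by colorimetric assay and MTT assay; a lower number here means a stronger inhibitor, a higher number a weaker inhibitor:
- Compound 1 `CCOC(=O)Cn1c(=O)c(-c2ccc(OC)cc2)cc2c(OC)cc(OC)cc21`: 10000 nM
- Compound 2 `CCN(CC)C(=O)Cn1c(=O)c(-c2ccc(OC)cc2)cc2c(OC)cc(OC)cc21`: 10000 nM
- Compound 3 `COc1ccc(-c2cc3c(OC)cc(OC)cc3n(CC(=O)O)c2=O)cc1`: 10000 nM

Compound 3 stands level with compound 1 and compound 2. Compound 4 `COC(=O)CCn1c(=O)c(-c2ccc(OC)cc2)cc2c(OC)cc(OC)cc21` differs from compound 3 in one place: (methoxycarbonyl)methyl in place of carboxy on a saturated chain carbon bound to an aromatic nitrogen. In words, (methoxycarbonyl)methyl replaces carboxy on a saturated chain carbon bound to an aromatic nitrogen.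

Going by the values given here, the steps that bear on this change the end of the chain: no change at the digits printed from compound 1 to compound 2 (within the scatter), no change at the digits printed from compound 1 to compound 3 (within the scatter) and no change at the digits printed from compound 2 to compound 3 (within the scatter). None goes beyond the scatter. Among the compounds with values here, no measured compound carries the 2-(methoxycarbonyl)ethyl chain, so this guide is incomplete. In this assay, the expected step is no change at the digits printed from compound 3 to compound 4 (within the scatter), with no direction expected beyond the scatter. For compound 4 the estimated value is 10000 nM, with an expected range of 4000 nM to 20000 nM.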

Compound 4, half-maximal inhibitory concentration: 10000 nM
The estimate for compound 4 equals the measured number at the digits printed; the measured number falls inside the stated range.
By their numbers in this assay, from the lowest: compounds 1, 2, 3 and 4 (each within the scatter of the next).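

In this assay there is no change at the digits printed from compound 3 to compound 4 (within the scatter) and no change at the digits printed from compound 2 to compound 4 (within the scatter) and also no change at the digits printed from compound 1 to compound 4 (within the scatter) as well. The earlier compounds shown here varied only the end group on the carboxymethyl chain, whereas the change from carboxymethyl to 2-(methoxycarbonyl)ethyl also alters the chain itself and still leaves the reading flat. No measurement here offers an explanation for this flat result. Still open, from the compounds shown here alone, is whether a terminal amine, a 2-carboxyethyl chain or a still longer chain at this position would give a different reading in this assay.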